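Swapping the Pendant Aryl Ring on an Aminothiophene Core

This account rests on a few compounds, and the source may have more. Where it says the series, first, only, none or still open, it means among the compounds named here.

Compound 1: `Nc1scc(-c2ccc(Br)cc2)c1C(=O)c1ccccc1` — 46%
Compound 2: `Nc1scc(-c2cccc(Cl)c2)c1C(=O)c1ccc(Cl)cc1` — 58%

Of the compounds shown here, two sharing the same aminothiophene-ketone core have been measured in a functional assay on CHO cells for agonist activity at adenosine receptor A1 (Homo sapiens), read by fluorescence and ERK phosphorylation, with stated times of 30 min and 1.5 h, tested at 3 uM; a higher number here means a stronger effect of the compound at the concentration tested, a lower number a weaker effect. Compound 1 gives 46% in this assay. Compound 2 gives 58% in this assay, the higher of the two numbers; the gap to compound 1 lies beyond the usual scatter. Among the compounds with values here, no single-point step between the two has been computed, since they differ in two places at once.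

Compound 3, `Nc1scc(-c2ccc(Br)cc2)c1C(=O)c1ccc(Cl)cc1`, has not yet been measured. It differs from compound 2 in one place: 4-bromophenyl in place of 3-chlorophenyl on an aromatic carbon. Compound 3 thus carries the same 4-bromophenyl group as compound 1 while keeping the rest of compound 2.

Within the data shown here, with only two measured compounds and no directly comparable step, the expectation rests on the two values alone. The step of a number 6 percentage points lower from compound 2 to compound 3 (within the scatter) is expected to be small and downward, probably within the scatter. Compound 3 is expected to give about 52% in this assay, with a likely range from 38% to 66%.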

Compound 3, a percentage reported as activity, at one concentration (the size of the read-out at that concentration, not a potency): 45%
Compound 3: middle estimate off by 7 percentage points, on the high side; low and high end bracket the measured number.
By their numbers in this assay, from the lowest: compounds 3 and 1 (each within the scatter of the next); then compound 2.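

In this assay, 4-bromophenyl in place of 3-chlorophenyl on an aromatic carbon of the five-membered ring with 1 sulfur now stands as a clean single change, giving a number 13 percentage points lower from compound 2 to compound 3 (beyond the scatter), so the aryl group at this position affects the read-out when the rest of compound 2 is kept. The other change, chloro in place of hydrogen on an aromatic carbon, gives a number 1 percentage points lower from compound 1 to compound 3 (within the scatter), so with the 4-bromophenyl group present, this chloro has no effect that can be told from the scatter. No measured evidence accompanies these compounds to explain either step.

The aryl swap alters both the halogen and its place on the phenyl ring, so the step cannot show which of the two matters, and a 3-bromophenyl or 4-chlorophenyl group would be needed to pull them apart. Also open, on these data alone, are whether the chloro stays without effect alongside 3-chlorophenyl, and how this position responds to a group that carries no halogen, such as an aminophenyl or a carboxylic acid.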